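Shortening the Chain on a Shared Core

The source may hold more compounds than are shown below. What is called first, only, known or untested is meant among the compounds shown, and "the series" means these compounds.

Three compounds of one shared core were tested in a functional assay on CNE-2 cells (Homo sapiens) for inhibition, read by MTT assay, with a stated time of 72 h; on this read-out higher numbers stand for weaker inhibition and lower numbers for stronger inhibition. Compound 1 `Nc1ncnc2c1c(-c1cnc3[nH]ccc3c1)nn2CCCC(=O)NO` carries the shortest chain. In this assay compound 1 gives only a limit, > 150000 nM. Compound 2 `Nc1ncnc2c1c(-c1cnc3[nH]ccc3c1)nn2CCCCCC(=O)NO` extends that chain by two carbons. In this assay compound 2 likewise gives only a limit, > 50000 nM. For the measured compounds named here, compound 3 `Nc1nc2cc(-c3nn(CCCCCCC(=O)NO)c4ncnc(N)c34)ccc2o1`, built on a different core, is the only one with a numerical value, and in this assay compound 3 gives 4360 nM. Going by the values given here, the one measured step that bears on chain length, a step that the two limits leave unreadable from compound 1 to compound 2, cannot be read because both of its ends are limits, the limit of > 150000 nM in this assay, at which 1 of the 3 values shown sits, and (the limit of > 50000 nM in this assay, at which 1 of the 3 values shown sits). Compound 4 `Nc1ncnc2c1c(-c1cnc3[nH]ccc3c1)nn2CCCCC(=O)NO` is the unmeasured compound; its chain sits between those of compound 1 and compound 2. The change from compound 2 is hydroxycarbamoyl in place of (hydroxycarbamoyl)methyl on a saturated chain carbon, four bonds along the chain from an aromatic nitrogen. With nothing readable on either side of it, no direction can be set for this change, and a weak result with a fair chance of another limit remains the likeliest outcome. Compound 4 is therefore expected to come out near 60000 nM, anywhere from 15000 nM to 200000 nM. That estimate means an expected step that the limit leaves unreadable from compound 2 to compound 4.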

Compound 4, half-maximal inhibitory concentration: > 150000 nM
Compound 4: only a limit was reported; the forecaster's own chance of this, stated with the estimate: 60%; middle value at least 2.5-fold (0.39 log units) away from the limit.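

Compound 4 also gives only a limit: the limit of > 150000 nM in this assay, at which 2 of the 4 values shown sit.

For the compounds shown here, with only limits for compound 1, compound 2 and compound 4, no new step among them can be read. The compounds shown leave open whether changing the chain length on this shared core changes inhibition at all, and in which direction.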